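The compounds below may be only part of what the source reports. "The series", "measured", "known", "first", "only" and "open" are said of these compounds alone.

Measured so far:
compound 1 `c1ccc(CSc2nnc(-c3ccc4c(c3)OCCO4)n2-c2ccccc2)cc1` — 73400 nM
compound 2 `O=[N+]([O-])c1cccc(CSc2nnc(-c3ccc4c(c3)OCCO4)n2-c2ccccc2)c1` — 30100 nM

Going by the values given here, in a functional assay on BGC-823 cells (Homo sapiens) for antiproliferative activity, read by MTT assay, with a stated time of 24 h (on this read-out higher numbers stand for weaker inhibition and lower numbers for stronger inhibition), compound 2 stands at the lowest of the two numbers, and its only neighbour is compound 1, the gap being a 2.4-fold lower number from compound 1 to compound 2 (0.39 log units; beyond the scatter). Compound 3 `Clc1cccc(CSc2nnc(-c3ccc4c(c3)OCCO4)n2-c2ccccc2)c1` differs from compound 2 by chloro in place of nitro on an aromatic carbon. Among the compounds with values here, the single measured step, which swapped hydrogen for nitro at this same position, is the only one that bears on the change, and it was modest. Chloro is neither hydrogen nor nitro, so the expected step of a 1.5-fold higher number from compound 2 to compound 3 (0.17 log units; within the scatter) is a small rise, probably within the scatter. Compound 3 is estimated at 45000 nM (range 20000 nM to 100000 nM).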

Compound 3, half-maximal inhibitory concentration: 51200 nM
Estimate against measurement, compound 3: 1.1-fold (0.06 log units) below; low and high end bracket the measured number.
By their numbers in this assay, from the lowest: compounds 2, 3 and 1 (each within the scatter of the next, the first and the last beyond it).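

In this assay chloro on this aromatic carbon cannot be separated from nitro (a 1.7-fold higher number from compound 2 to compound 3 (0.23 log units; within the scatter)) or from hydrogen (a 1.4-fold lower number from compound 1 to compound 3 (0.16 log units; within the scatter)). Compound 3 thus lies within the scatter of both compounds, although those two lie beyond the scatter of each other, so it adds no clear step at this position. No measurement bears on the reason for this result.

On these data alone, it remains open how an amine or a carboxylic acid on this carbon would read. As far as these compounds go, the effect of chloro or nitro elsewhere on the six-membered ring also remains open.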